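Swapping an ethyl for an acetoxy on the aryl ring

This account rests on a few compounds, and the source may have more. Where it says the series, first, only, none or still open, it means among the compounds named here.

The two measured compounds share a core and differ only in one group. Compound 1 `COc1cccc(OC)c1OCCNC[C@H]1Oc2ccccc2O[C@@H]1C(C)C` carries an isopropyl there; in a functional assay for antagonist activity at Adrenergic receptor alpha-1 (Rattus norvegicus) (on this read-out higher numbers stand for weaker binding and lower numbers for tighter binding), compound 1 gives 269 nM. Compound 2 `CCc1ccc([C@H]2Oc3ccccc3O[C@@H]2CNCCOc2c(OC)cccc2OC)cc1` carries a 4-ethylphenyl instead, and in this assay compound 2 gives 15.1 nM, the lowest of the two numbers; the step of an 18-fold lower number from compound 1 to compound 2 (1.25 log units; beyond the scatter) is a large gain. Compound 3 `COc1cccc(OC)c1OCCNC[C@H]1Oc2ccccc2O[C@@H]1c1ccc(OC(C)=O)cc1` is the unmeasured one: acetoxy in place of ethyl on an aromatic carbon. Going by the values given here, no measured step touches the far end of the aryl ring, so the only guide is that compound 2 already sits low after the gain of an 18-fold lower number from compound 1 to compound 2 (1.25 log units; beyond the scatter). With the aryl ring kept, only a modest shift is expected, and a 1.7-fold higher number from compound 2 to compound 3 (0.22 log units; within the scatter) is the estimated step. Compound 3 is therefore expected to show about 25 nM in this assay, within a range from 8 nM to 80 nM.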

Compound 3, dissociation constant: 7.59 nM
Estimate against measurement, compound 3: 3.3-fold (0.52 log units) above; measured number below the stated range.
By their numbers in this assay, from the lowest: compounds 3 and 2 (each within the scatter of the next); then compound 1.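

Acetoxy is larger than ethyl, with four heavy atoms instead of two and two hydrogen-bond acceptors where ethyl has none, yet the step of a 2.0-fold lower number from compound 2 to compound 3 (0.30 log units; within the scatter) in this assay stays within the scatter, so compound 2 and compound 3 cannot be ranked. This aromatic carbon, para to a large group, therefore accepts this change without any clear loss, and the far end of the aryl ring need not be a plain hydrocarbon. The step of a 35-fold lower number from compound 1 to compound 3 (1.55 log units; beyond the scatter) shows that the large gain over isopropyl holds with 4-acetoxyphenyl as well as with 4-ethylphenyl, and nothing available explains why ethyl and acetoxy read so alike.

On these data alone, what a hydroxyl, an amine or a carboxylic acid would do at this carbon remains open. So does the effect of a longer chain such as butyl.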